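Amide nitrogen substituent and maximal response in the series

The source may report more compounds than this note shows. Statements on the series, on what has been measured and on what is new or still open speak of the compounds shown alone.

Compound 1 `CC(C)[C@H](C(=O)NC(C)(C)C)c1ccc(Cl)cc1` carries tert-butyl on the amide nitrogen. In a functional assay on CHO cells for agonist activity at Free fatty acid receptor 2 (Homo sapiens), read by cAMP accumulation (a lower number here means a smaller maximal response, a higher number a larger maximal response), compound 1 gives < 30%, a limit of the assay. Compound 2 `CC(C)[C@H](C(=O)Nc1ccccc1)c1ccc(Cl)cc1` gives < 30% in this assay, also a limit. Among the measured compounds shown here, compound 3 `CC(C)[C@H](C(=O)Nc1cccnn1)c1ccc(Cl)cc1` gives 101% in this assay, the only number among the three. The other two values sit at the limit of < 30% in this assay, at which 2 of the 3 values shown sit. The steps of a number at least 71 percentage points higher from compound 1 to compound 3 (beyond the scatter) and a number at least 71 percentage points higher from compound 2 to compound 3 (beyond the scatter) are both large, while a step that the two limits leave unreadable from compound 1 to compound 2 cannot be sized. Compound 4 `CC(C)[C@H](C(=O)Nc1ncc[nH]1)c1ccc(Cl)cc1` differs from compound 3 by 1H-imidazol-2-yl in place of pyridazin-3-yl on an amide-type nitrogen. Both rings that gave a number or a limit differ from this one, so the step is uncertain. For compound 4 an efficacy of 70% is expected, between 30% and 105%, which means an expected step of a number 31 percentage points lower from compound 3 to compound 4 (beyond the scatter).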

Compound 4, largest response reached (reported as efficacy), in percent of the reference or control that the assay uses: 55%
Compound 4: middle estimate off by 15 percentage points, on the high side; the range from low to high includes it.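

In this assay, a second ring with 2 hetero atoms on the amide nitrogen also gives a clear response: a number at least 25 percentage points higher from compound 2 to compound 4 (beyond the scatter), and a number at least 25 percentage points higher from compound 1 to compound 4 (beyond the scatter). The two rings are not interchangeable, however: a number 46 percentage points lower from compound 3 to compound 4 (beyond the scatter). Compound 1 and compound 2 remain limits of the assay: the limit of < 30% in this assay, at which 2 of the 4 values shown sit.

Ring size and the ring hydrogen-bond donor change together in the step to compound 4, and the compounds shown do not separate them. A pyridin-2-yl or 1-methylimidazol-2-yl group on the amide nitrogen would bear on this question.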